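The source may hold more compounds than are shown below. What is called first, only, known or untested is meant among the compounds shown, and "the series" means these compounds.

Values so far:
- compound 1 `Cc1cc(Nc2cc(-c3ccccc3)[nH]n2)n2nc(SCc3ccc(Br)cc3)nc2n1` gives 1110 nM
- compound 2 `Cc1cc(Nc2cc(-c3ccccc3)[nH]n2)n2nc(SCc3ccc(C(F)(F)F)cc3)nc2n1` gives 3520 nM
- compound 3 `Cc1cc(Nc2cc(-c3ccccc3)[nH]n2)n2nc(SCC3CC3)nc2n1` is not yet measured

In a functional assay on MGC-803 cells (Homo sapiens) for inhibition, read by MTT assay, with a stated time of 72 h (on this read-out lower numbers stand for stronger inhibition and higher numbers for weaker inhibition), compound 2 has the higher of the two numbers. The change to compound 3 (cyclopropyl in place of 4-(trifluoromethyl)phenyl on a saturated chain carbon bound to a sulfur) is cyclopropyl in place of 4-(trifluoromethyl)phenyl on a saturated chain carbon bound to a sulfur. Among the measured compounds shown here, the one measured step is a 3.2-fold higher number from compound 1 to compound 2 (0.50 log units; beyond the scatter) and it is modest, but it only exchanges a group on an aromatic carbon. For the measured compounds named here, no measured step removes the aromatic ring, so it is a weak guide. In this assay no step beyond the scatter is expected as the central case, with the direction uncertain. The estimated step is a 1.4-fold higher number from compound 2 to compound 3 (0.15 log units; within the scatter) and it carries wide uncertainty. Compound 3 is estimated at 5000 nM with an expected range from 1200 nM to 20000 nM for now.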

Compound 3, half-maximal inhibitory concentration: 16100 nM
Compound 3: middle estimate off by 3.2-fold (0.51 log units), on the low side; measured number inside the range.
By their numbers in this assay, from the lowest: compound 1; then compound 2; then compound 3.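

In this assay, this is the first change shown to the group on the saturated chain carbon bound to a sulfur, rather than to a substituent on its aromatic ring. Cyclopropyl gives a weaker result than either aromatic group, with a 4.6-fold higher number from compound 2 to compound 3 (0.66 log units; beyond the scatter) and a 15-fold higher number from compound 1 to compound 3 (1.16 log units; beyond the scatter) in the same direction. Nothing available explains these steps.

Cyclopropyl differs from both aromatic groups in ring type and in size at once, and the two cannot be separated here. Unsubstituted benzyl or a longer chain at this place could separate them.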